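The source may hold more compounds than are shown below. What is called first, only, known or untested is meant among the compounds shown, and "the series" means these compounds.

Compound 1 `Nc1nn(CCOCCO)c2nnc(-c3ccccc3)c(-c3ccccc3)c12` was tested in a functional assay on PC-3 cells (Homo sapiens) for cytotoxicity; on this read-out lower numbers stand for stronger inhibition and higher numbers for weaker inhibition. In this assay compound 1 gives only a limit, > 100000 nM, and this is where it stands among the values shown, at the limit of > 100000 nM in this assay, at which 1 of the 2 values shown sits. Compound 2 `Nc1[nH]nc2nnc(-c3ccc(-c4ccccc4)cc3)c(-c3ccc(-c4ccccc4)cc3)c12` has no result in this assay, "not determined" (no result reported). Compound 3 `CC(=O)n1nc(N)c2c(-c3ccccc3)c(-c3ccccc3)nnc21` differs from compound 1 by acetyl in place of 2-(2-hydroxyethoxy)ethyl on an aromatic nitrogen. Going by the values given here, no measured step covers this change, so its size and direction are open to view; the step is expected to stay near the scatter, an at least 1.1-fold lower number from compound 1 to compound 3 (0.04 log units; that floor lies within the scatter). Compound 3 is estimated at 90000 nM, between 20000 nM and 300000 nM, with a limit again the likely outcome.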

Compound 3, half-maximal inhibitory concentration: > 100000 nM
Compound 3 was reported as a limit (the forecaster's own chance of this, stated with the estimate: 65%); middle value at least 1.1-fold (0.04 log units) away from the limit.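

Going by these compounds alone, no step from compound 1 to compound 3 can be read, because both are reported only as limits: the limit of > 100000 nM in this assay, at which 2 of the 3 values shown sit. The compounds shown leave open how acetyl and 2-(2-hydroxyethoxy)ethyl on the aromatic nitrogen compare in this assay.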